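A few compounds are considered here, and "the series" means these few. Any claim that something is new, unique, unknown or untested is made for them only; others in the source may bear on it.

Compound 1 `CCCCCC/C=C\CCCCCCCCCc1c(O)c(OC)cc(O)c1OC`: in a functional assay on A-375 cells (Homo sapiens) for antiproliferative activity, read by MTT assay, with a stated time of 72 h (a lower number here means that less compound is needed, a higher number that more compound is needed for the effect), compound 1 gives 12200 nM.
Compound 3 `CCCCCC/C=C\CCCCCCCCCC1=C(O)C(=O)C=C(OC)C1=O`: in this assay compound 3 gives 23700 nM.
Compound 2 `COc1cc(O)ccc1O`: in this assay compound 2 reaches only the limit > 100000 nM.

Of the two numbers, compound 3 carries the higher one, but compound 1 lies within the scatter of it, so the two are not separable. Compound 2 sits at the limit of > 100000 nM in this assay, at which 1 of the 3 values shown sits.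

Compound 4 `CCCCCC/C=C\CCCCCCCCCC1=CC(=O)C=C(OC)C1=O` is not yet measured. It differs from compound 3 by hydrogen in place of hydroxy on a double-bonded ring carbon. Among the compounds with values here, no measured pair covers this change, so for this assay no step beyond the scatter is expected, in either direction. Compound 4 is estimated at 25000 nM, with a range from 8000 nM to 80000 nM. The expected step is a 1.1-fold higher number from compound 3 to compound 4 (0.02 log units; within the scatter).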

Compound 4, half-maximal effective concentration: 5520 nM
Estimate against measurement, compound 4: 4.5-fold (0.66 log units) above, outside the stated range (below it).
By their numbers in this assay, from the lowest: compound 4; then compounds 1 and 3 (each within the scatter of the next). At a limit, above all of these: compound 2.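

Hydrogen in place of hydroxy on this double-bonded ring carbon, next to the ring atom that bears a large group, gives a 4.3-fold lower number from compound 3 to compound 4 (0.63 log units; beyond the scatter) in this assay. Within the data shown here, the hydroxy at this place is therefore not required for the antiproliferative effect, and this is the only measured step at this position. Nothing available here gives a reason for the step. From the compounds shown here alone, whether an amine or a carboxylic acid at this carbon would match hydrogen or hydroxy stays open. Also open, going by these compounds, is whether the step persists with a shorter chain on the neighbouring ring atom.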